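The compounds below may be only part of what the source reports. "The series", "measured", "known", "first", "only" and "open" are said of these compounds alone.

Measured compounds:
Compound 1, `O=C(O)CCC(=O)N(C1CC1)[C@H]1c2ccccc2N(C(=O)c2cccc(OC(F)(F)F)c2)[C@H]2CC[C@H]21`: 18 nM
Compound 2, `O=C(O)CCC(=O)N(C1CC1)[C@H]1c2ccccc2N(C(=O)c2ccc(OC(F)(F)F)cc2)[C@H]2CC[C@H]21`: 3.9 nM

In a functional assay for antagonist activity at prostaglandin D2 receptor 2 (Homo sapiens), read by flow cytometry, with stated times of 10 min and 4 min (a higher number here means a weaker inhibitor, a lower number a stronger inhibitor), compound 2 gives the lowest number of the two, with compound 1 the nearest at a 4.6-fold lower number from compound 1 to compound 2 (0.66 log units; beyond the scatter). Compound 3, `O=C(O)COC(=O)N(C1CC1)[C@H]1c2ccccc2N(C(=O)c2ccc(OC(F)(F)F)cc2)[C@H]2CC[C@H]21`, is not yet measured in this assay. It differs from compound 2 by carboxymethoxy in place of 2-carboxyethyl on a carbonyl carbon. Going by the values given here, the only measured step, from compound 1 to compound 2, changes the aroyl group and not the side chain on the carbonyl carbon, so no measured step bears directly on this change; the only guidance is that the acid-bearing chain keeps its length and its donor while gaining an acceptor. With nothing to anchor the direction, the expected step is a 2.1-fold higher number from compound 2 to compound 3 (0.31 log units; beyond the scatter), small and uncertain. Compound 3 is therefore estimated at 8 nM in this assay, with a range of 2 nM to 30 nM.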

Compound 3, half-maximal inhibitory concentration: 8.2 nM
The estimate for compound 3 lay 1.0-fold (0.01 log units) below the measured number; the measured number falls inside the stated range.
By their numbers in this assay, from the lowest: compound 2; then compound 3; then compound 1.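

In this assay, going by these compounds alone, this is the first look at the side chain on the carbonyl carbon, since the earlier pair varied only the aroyl group. Carboxymethoxy in place of 2-carboxyethyl gives a 2.1-fold higher number from compound 2 to compound 3 (0.32 log units; beyond the scatter), so the exchange of one chain carbon for an oxygen, at the same heavy-atom count and with the carboxylic acid kept, costs a modest amount, and compound 3 still gives 8.2 nM. No supporting data explain this step.

On these data alone, it remains open whether the same step would appear with the 3-(trifluoromethoxy)phenyl group of compound 1 on the other carbonyl. Also open, as far as these compounds go, is how the position would respond to a longer chain such as 3-carboxypropyl, or to a tetrazole or a primary amide in place of the carboxylic acid.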